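A Saturated Ring Gives Way to an Aromatic One

The compounds below may be only part of what the source reports. "The series", "measured", "known", "first", "only" and "open" are said of these compounds alone.

In an in vitro functional assay on cells for agonist activity at Bombesin receptor subtype-3 (Homo sapiens), read by luminescence and calcium flux (a higher number here means that more compound is needed for the effect, a lower number that less compound is needed), compound 1 `O=C(O)c1ccccc1-c1ccc(CCc2ncc(CCC3CCCCC3)[nH]2)cc1` gives 642 nM, the second highest of the three numbers recorded. Compound 3 `O=C(O)c1ccccc1-c1ccc(CCc2ncc(CC3CCOCC3)[nH]2)cc1` gives 338 nM in this assay, and the change between them is a 1.9-fold lower number from compound 1 to compound 3 (0.28 log units; within the scatter), a step that stays within the scatter. Compound 2 `CCCCc1cnc(C(CCCO)Cc2ccc(-c3ccccc3C(=O)O)cc2)[nH]1` gives 1900 nM in this assay, a gap from compound 1 that lies beyond the scatter. Compound 4 `O=C(O)c1ccccc1-c1ccc(CCc2ncc(Cc3cccc(Cl)c3)[nH]2)cc1` has not yet been measured; it differs from compound 1 by 3-chlorophenyl in place of cyclohexylmethyl on a saturated chain carbon bound to an aromatic carbon. Within the data shown here, the only measured step at that same place, a 1.9-fold lower number from compound 1 to compound 3 (0.28 log units; within the scatter), was within the scatter, and no measured pair probes an aromatic group there. The account therefore expects a 1.3-fold lower number from compound 1 to compound 4 (0.11 log units; within the scatter), with no direction secured. For compound 4 in this assay the estimate is 500 nM, expected to fall between 180 nM and 1500 nM.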

Compound 4, half-maximal effective concentration: 825 nM
Estimate against measurement, compound 4: 1.7-fold (0.22 log units) below; the measured number falls inside the stated range.
By their numbers in this assay, from the lowest: compounds 3, 1 and 4 (each within the scatter of the next, the first and the last beyond it); then compound 2.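

An aromatic ring can take the place of the saturated one at this position in this assay: the step (a 1.3-fold higher number from compound 1 to compound 4 (0.11 log units; within the scatter)) does not separate 3-chlorophenyl from cyclohexylmethyl. Against oxan-4-yl the same group does separate, and the step (a 2.4-fold higher number from compound 3 to compound 4 (0.39 log units; beyond the scatter)) is the only one at this place so far to lie beyond the scatter. The compounds leave open whether an amine or a carboxylic acid on the aromatic ring, or a longer chain at this place, would shift the number. Nothing available explains either step.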